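The source may hold more compounds than are shown below. What is called first, only, known or untested is meant among the compounds shown, and "the series" means these compounds.

For the measured compounds named here, compound 2 `Cc1oc(-c2c(Cl)cccc2Br)nc1CN1CCC(C(=O)NCCCN2C[C@H](C)C[C@H](C)C2)CC1` gives 12200 nM in an ADME assay on Huh7.5.1 cells (Homo sapiens) for cytotoxicity, read by ATP content, with a stated time of 48 h (a lower number here means that less compound is tolerated, a higher number that more compound is tolerated), the lowest of the two numbers so far; compound 1 `Cc1oc(-c2c(Cl)cccc2Cl)nc1CN1CCC(C(=O)NCCCN2C[C@H](C)C[C@H](C)C2)CC1` gives 13200 nM, and the step of a 1.1-fold lower number from compound 1 to compound 2 (0.03 log units; within the scatter) lies within the scatter. Compound 3 `COc1cccc(C)c1-c1nc(CN2CCC(C(=O)NCCCN3C[C@H](C)C[C@H](C)C3)CC2)c(C)o1` carries 2-methoxy-6-methylphenyl in place of 2-bromo-6-chlorophenyl on an aromatic carbon. No measured step exchanges a halogenated ring for a methoxy- and methyl-bearing one, so only the small halogen step offers guidance, and it gives no reason to expect a step beyond the scatter. Compound 3 is therefore expected to tolerate about 13000 nM in this assay, between 6000 nM and 28000 nM, a step of a 1.1-fold higher number from compound 2 to compound 3 (0.03 log units; within the scatter).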

Compound 3, half-maximal cytotoxic concentration: 16700 nM
The estimate for compound 3 lay 1.3-fold (0.11 log units) below the measured number; the range from low to high includes it.
By their numbers in this assay, from the lowest: compounds 2, 1 and 3 (each within the scatter of the next).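

The exchange for 2-methoxy-6-methylphenyl gives a 1.4-fold higher number from compound 2 to compound 3 (0.14 log units; within the scatter) and, from the 2,6-dichlorophenyl group, a 1.3-fold higher number from compound 1 to compound 3 (0.10 log units; within the scatter) in this assay. The earlier compounds shown here showed only one halogen exchanged for another, whereas these steps show that, at this position on the five-membered ring, a phenyl group without halogen also stays within the scatter. Nothing available bears on why this is so. The compounds shown leave open whether an unsubstituted phenyl ring, or a phenyl ring carrying an amine or a carboxylic acid, would also stay within the scatter.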